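The source may hold more compounds than are shown below. What is called first, only, known or untested is meant among the compounds shown, and "the series" means these compounds.

Measured in an ADME assay on Vero cells (Chlorocebus sabaeus) for cytotoxicity, read by MTT assay; a higher number here means that more compound is tolerated, a lower number that less compound is tolerated:
- compound 1 `Cn1nc(C(F)(F)F)cc1C(=O)Nc1ccc(S(=O)(=O)N2CCCCCCC2)cc1`: 16000 nM
- compound 2 `Cn1nc(C(F)(F)F)cc1C(=O)Nc1ccc(S(=O)(=O)NC2CCCCC2)cc1`: 15000 nM
- compound 3 `Cn1nc(C(F)(F)F)cc1C(=O)Nc1ccc(S(=O)(=O)OC2CCCCC2)cc1`: > 300000 nM (a limit, not a number)

Compound 3 has no exact figure, only a limit: the limit of > 300000 nM in this assay, at which 1 of the 3 values shown sits. Its steps from the other two compounds are both large, so it is the best tolerated of the three.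

The next compound is compound 4 `Cn1nc(C(F)(F)F)cc1C(=O)Nc1ccc(S(=O)(=O)N2CCOCC2)cc1`. It carries morpholin-4-yl in place of cyclohexyloxy on a sulfonyl sulfur.

Among the measured compounds shown here, two measured steps bear most directly on this change. The closest is an at least 20-fold higher number from compound 2 to compound 3 (1.30 log units; beyond the scatter), where cyclohexyloxy replaces cyclohexylamino. The other is an at least 18-fold higher number from compound 1 to compound 3 (1.27 log units; beyond the scatter). Both point the same way: the two compounds with a nitrogen-linked group on the sulfonyl sulfur sit far lower than compound 3. Those two nitrogen-linked groups also differ from each other, yet a 1.1-fold lower number from compound 1 to compound 2 (0.03 log units; within the scatter) stays within the scatter.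

Compound 4 returns to a nitrogen-linked group, so a large move in the reverse direction is expected. The estimated step is an at least 8.5-fold lower number from compound 3 to compound 4 (0.93 log units; beyond the scatter), towards a lower number in this assay. For the measured compounds named here, no measured compound yet carries morpholin-4-yl, so the expected range is kept wide, especially upwards. Compound 4 is estimated at 35000 nM, with an expected range of 12000 nM to 150000 nM.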

Compound 4, half-maximal cytotoxic concentration: > 300000 nM
Compound 4: no number, only a limit (the forecaster's own chance of this, stated with the estimate: 15%); at least 8.5-fold (0.93 log units) between middle value and limit.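

Until now, both groups linked through nitrogen on the sulfonyl sulfur sat low in this assay, but morpholin-4-yl, also linked through nitrogen, gives an at least 20-fold higher number from compound 2 to compound 4 (1.30 log units; beyond the scatter) and an at least 18-fold higher number from compound 1 to compound 4 (1.27 log units; beyond the scatter) on the same core. Among these four compounds, a nitrogen link therefore does not by itself mean a low number, and compound 4 is the one that goes against the earlier contrast between nitrogen and oxygen links. The steps between compound 3 and compound 4 cannot be read, and the two cannot be put in order, because each has only a limit and not a number: the limit of > 300000 nM in this assay, at which 2 of the 4 values shown sit.

As far as these compounds go, it remains open whether the ring oxygen of morpholin-4-yl matters, and a piperidine ring on the same sulfonyl sulfur would separate that oxygen from the ring size. Also open, from the compounds shown here alone, is how an open-chain amine such as diethylamino, or a piperazine ring with its second nitrogen, would compare with compound 1, compound 2 and compound 4.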